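A few compounds are considered here, and "the series" means these few. Any claim that something is new, unique, unknown or untested is made for them only; others in the source may bear on it.

Within the data shown here, compound 3 `Cc1c(Nc2nc(N)c3c(C#N)c(N4CCC[C@H]4C)n(C)c3n2)cnn1CC(C)(C)O` gives 35 nM in an assay on isolated protein for inhibition of Leucine-rich repeat serine/threonine-protein kinase 2 variant G2019S (Homo sapiens), read by TR-FRET and LanthaScreen, with stated times of 50 min and 30 min, in the presence of a further agent that is not named here (on this read-out higher numbers stand for weaker inhibition and lower numbers for stronger inhibition), and stands second highest of the three numbers so far. Compound 1 `Cc1c(Nc2nc(N)c3c(C#N)c(N4CCC[C@H]4C)n(C)c3n2)cnn1C` gives 43 nM, within the scatter of compound 3. Compound 2 `Cc1c(Nc2nc(N)c3c(C#N)c(N4CCC[C@H]4C)n(C)c3n2)cnn1CC1(O)COC1` gives 10 nM, and the step of a 3.5-fold higher number from compound 2 to compound 3 (0.54 log units; beyond the scatter) lies beyond the scatter. Compound 4 `Cc1c(Nc2nc(N)c3c(C#N)c(N4CCC[C@H]4C)n(C)c3n2)cnn1[C@@H]1CCOC1` changes the same place: oxolan-3-yl in place of 2-hydroxy-2-methylpropyl on an aromatic nitrogen. The measured steps at this place were a 4.3-fold lower number from compound 1 to compound 2 (0.63 log units; beyond the scatter) and a 1.2-fold lower number from compound 1 to compound 3 (0.09 log units; within the scatter), so groups on the aromatic nitrogen have so far either modestly lowered the number or left it unchanged. Among the measured compounds shown here, compound 4 carries a ring with no hydroxyl, which no measured compound shares, so a small expected step of a 1.1-fold higher number from compound 3 to compound 4 (0.06 log units; within the scatter) comes with wide uncertainty. Compound 4 is estimated at 40 nM, in the range 13 nM to 120 nM.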

Compound 4, half-maximal inhibitory concentration: 12 nM
For compound 4 the middle estimate is 3.3-fold (0.52 log units) above the measured one; the measured number lies below the stated range.
By their numbers in this assay, from the lowest: compounds 2 and 4 (each within the scatter of the next); then compounds 3 and 1 (each within the scatter of the next).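

Replacing 2-hydroxy-2-methylpropyl with oxolan-3-yl, which has the same count of heavy atoms, gives a 2.9-fold lower number from compound 3 to compound 4 (0.46 log units; beyond the scatter) in this assay and so shows that atom count alone does not set the number at this aromatic nitrogen. With no hydrogen-bond donor, the ring also gives a 3.6-fold lower number from compound 1 to compound 4 (0.55 log units; beyond the scatter) and stands level with the hydroxyl-bearing group of compound 2 (a 1.2-fold higher number from compound 2 to compound 4 (0.08 log units; within the scatter)), so a low number does not need a donor here, while compound 3 shows that a donor does not ensure one. Nothing shown accounts for these steps.

From the compounds shown here alone, the mirror-image oxolan-3-yl remains open, as does a ring carrying an amine, such as pyrrolidin-3-yl.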